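From 3-Nitrophenyl to 2-(Trifluoromethyl)phenyl at the Assay Limit

The source may hold more compounds than are shown below. What is called first, only, known or untested is meant among the compounds shown, and "the series" means these compounds.

Of the compounds shown here, three have so far been tested in an ADME assay on MT4 cells (Homo sapiens) for cytotoxicity, read by MTT assay, with a stated time of 3 days; on this read-out higher numbers stand for lower toxicity in this test and lower numbers for higher toxicity in this test. Compound 1 (`CC(C)(NC(=O)COC(=O)c1ccc([N+](=O)[O-])o1)c1ccccc1`) gives > 100000 nM, which is a limit of the assay and not a number. Compound 2 (`O=C(COC(=O)c1ccc([N+](=O)[O-])o1)NC1CCc2ccccc21`) gives > 100000 nM, which is again a limit. Compound 3 (`CC(C)(C)N(Cc1cccc([N+](=O)[O-])c1)C(=O)COC(=O)c1ccc([N+](=O)[O-])o1`) gives > 100000 nM, also a limit and not a number. Compound 3 therefore stands with the other two at the limit of > 100000 nM in this assay, at which 3 of the 3 values shown sit.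

Compound 4 (`CC(C)(C)N(Cc1ccccc1C(F)(F)F)C(=O)COC(=O)c1ccc([N+](=O)[O-])o1`) has not yet been measured. It carries 2-(trifluoromethyl)phenyl in place of 3-nitrophenyl on a saturated chain carbon bound to an amide-type nitrogen. Within the data shown here, no measured pair of compounds differs in one place only, so the data give no direct size for such a change in this assay. No step beyond the usual scatter is expected, in either direction. The estimated change, an at least 1.1-fold lower number from compound 3 to compound 4 (0.04 log units; that floor lies within the scatter), is accordingly expected to be small. This expectation rests on compound 3, whose result is the limit > 100000 nM. For compound 4 the half-maximal cytotoxic concentration is estimated at 90000 nM, with an expected range from 35000 nM to 150000 nM.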

Compound 4, half-maximal cytotoxic concentration: 95000 nM
Compound 4: the middle estimate sits 1.1-fold (0.02 log units) below what was measured; measured number inside the range.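

In this assay compound 4 gives 95000 nM, the only result shown that is a number and not a limit, so this place, a saturated chain carbon bound to an amide-type nitrogen, now carries a substituent with a readable value. Putting 2-(trifluoromethyl)phenyl there in place of 3-nitrophenyl gives an at least 1.0-fold lower number from compound 3 to compound 4 (0.02 log units; that floor lies within the scatter), which is only a floor and does not show a change beyond the scatter. The true size of the step stays unknown because its starting point is a limit and not a number: the limit of > 100000 nM in this assay, at which 3 of the 4 values shown sit.

The compounds shown leave open whether a plain phenyl, a pyridine ring or an aromatic ring carrying an amine or a carboxylic acid at this place would give a number close to that of compound 4, and they cannot separate the loss of the nitro group from the arrival of the trifluoromethyl group. They also do not tell whether this value would hold if the nitro group on the shared core gave way to a nitrile.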